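The compounds below may be only part of what the source reports. "The series", "measured", "known", "first", "only" and "open" are said of these compounds alone.

Among the compounds with values here, in a functional assay on MCF7 cells (Homo sapiens) for inhibition, read by MTT assay, with a stated time of 4 days (a lower number here means a stronger inhibitor, a higher number a weaker inhibitor), compound 1 (`COc1cc(NC(C)CCCNC(=O)NN)c2ncccc2c1`) gives 16000 nM and compound 2 (`COc1cc(NC(C)CCCNC(=O)NNC(=O)NCCO)c2ncccc2c1`) gives 13000 nM so that the two lie within the scatter of each other at the high end of the three numbers so far. Compound 3 (`COc1cc(NC(C)CCCNC(=O)NNC(=O)NCCCC(C)Nc2cc(OC)cc3cccnc23)c2ncccc2c1`) gives 200 nM and stands well under compound 2, a gap beyond the scatter.

Compound 4 (`COc1cc(NC(C)CCCNC(=O)NNC(=O)N(CCO)CCO)c2ncccc2c1`) has not yet been measured. The change from compound 2 is 2-hydroxyethyl in place of hydrogen on an amide-type nitrogen with 2-hydroxyethyl in place of hydrogen on an amide-type nitrogen, which turns (2-hydroxyethyl)carbamoyl into bis(2-hydroxyethyl)carbamoyl.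

Within the data shown here, the one measured step that bears on this is a 1.2-fold lower number from compound 1 to compound 2 (0.09 log units; within the scatter) when (2-hydroxyethyl)carbamoyl replaces hydrogen on an amine nitrogen. Among the measured compounds shown here, it is a single step at a different place, and no measured pair shows this exact replacement. Compound 3 differs from compound 2 by much more than one group and gives no guide to it. On the size of that one step, no change beyond the scatter is expected in this assay and no direction is favoured.

The estimated step is no change at the digits printed from compound 2 to compound 4 (within the scatter) and it stays within the scatter. For compound 4 the expected value is 13000 nM with an estimated range from 6500 nM to 26000 nM for the coming measurement.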

Compound 4, half-maximal inhibitory concentration: 29000 nM
Estimate against measurement, compound 4: 2.2-fold (0.35 log units) below, and the stated range ends below it.
By their numbers in this assay, from the lowest: compound 3; then compounds 2, 1 and 4 (each within the scatter of the next, the first and the last beyond it).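

In this assay, within the data shown here, the second 2-hydroxyethyl on the amide-type nitrogen gives the first step in this side chain that passes the scatter, a modest one (a 2.2-fold higher number from compound 2 to compound 4 (0.35 log units; beyond the scatter)), whereas the first substitution at this end of the chain did not (a 1.2-fold lower number from compound 1 to compound 2 (0.09 log units; within the scatter)). Taken as a whole, bis(2-hydroxyethyl)carbamoyl in place of hydrogen on the amine nitrogen stays within the scatter (a 1.8-fold higher number from compound 1 to compound 4 (0.26 log units; within the scatter)), so among compound 1, compound 2 and compound 4 neither form of the carbamoyl group lowers the number beyond the scatter, and the only step beyond it points upward. Nothing available on these compounds accounts for the step from compound 2 to compound 4.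

Open, on these data alone, is whether the step follows the hydroxyl or the added carbons, which an ethyl or a 2-methoxyethyl group on the same nitrogen would separate. Also open, as far as these compounds go, is how a longer chain such as 3-hydroxypropyl, or a chain ending in an amine or a carboxylic acid, would read at this nitrogen in this assay.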